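The source may hold more compounds than are shown below. What is called first, only, known or untested is meant among the compounds shown, and "the series" means these compounds.

Measured so far in an ADME assay (liver) for metabolic stability, with Liver microsome (Homo sapiens) as the target, using microsomes; a lower number here means slower removal, a higher number faster removal of the compound:
compound 1 `Cc1cnc(NC(=O)c2cc(Oc3ccc(C(=O)N(C)C)nc3)c3cc(C)oc3c2)cn1` gives 11.6 mL/min/kg
compound 2 `Cc1ccc(Oc2cc(C(=O)Nc3cnc(C)cn3)cc3oc(C)cc23)cc1` gives 47 mL/min/kg

Compound 2 holds the higher of the two numbers, and compound 1 lies below it, beyond the scatter. Compound 3 `Cc1cnc(NC(=O)c2cc(Oc3ccc(C#N)cc3)c3cc(C)oc3c2)cn1` has cyano in place of methyl on an aromatic carbon, para to a large group (cyano in place of methyl on an aromatic carbon). Going by the values given here, no measured step covers this change, so the expectation starts from compound 2 (47 mL/min/kg) and takes compound 1 (11.6 mL/min/kg) as the lower mark. A lower number beyond the scatter is expected (a 2.1-fold lower number from compound 2 to compound 3 (0.33 log units; beyond the scatter)). The estimated value for compound 3 is 22 mL/min/kg (range 11 mL/min/kg to 42 mL/min/kg).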

Compound 3, clearance in the Liver microsome assay: 29 mL/min/kg
For compound 3 the middle estimate is 1.3-fold (0.12 log units) below the measured one; the measured number falls inside the stated range.
By their numbers in the Liver microsome assay, from the lowest: compound 1; then compounds 3 and 2 (each within the scatter of the next).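

Cyano in place of methyl on an aromatic carbon, para to a large group, gives in the Liver microsome assay a 1.6-fold lower number from compound 2 to compound 3 (0.21 log units; within the scatter), so this position does not separate 4-methylphenoxy from 4-cyanophenoxy on that read-out. In a physicochemical assay for solubility, measured as kinetic solubility (on this read-out higher numbers stand for higher solubility and lower numbers for lower solubility), compound 2 gives 18000 nM and compound 3 gives 2000 nM on that read-out. The same change does separate the two compounds in the physicochemical assay: the measured solubility of compound 2, 18000 nM, and of compound 3, 2000 nM, a 9.0-fold lower number (0.95 log units; beyond the scatter)

Still open, as far as these compounds go, is whether another group on this carbon, such as fluorine, methoxy or a carboxylic acid, would give a step beyond the scatter in the Liver microsome assay. Also open, from the compounds shown here alone, is how such a group would read in the physicochemical assay.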